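Phenol ether variation and cytotoxicity in the series

A few compounds are considered here, and "the series" means these few. Any claim that something is new, unique, unknown or untested is made for them only; others in the source may bear on it.

Compound 1 `CCOC(=O)CCCOc1ccc(-c2nc3ncccn3c2NC2CCCCC2)cc1` — in a toxicity assay on A549 cells (Homo sapiens) for cytotoxicity, read by luminescence and CellTiter-Glo, with a stated time of 48 h (a higher number here means that more compound is tolerated, a lower number that less compound is tolerated), compound 1 gives > 100000 nM, a limit of the assay.
Compound 2 `Oc1ccc(-c2nc3ncccn3c2NC2CCCCC2)cc1` — in this assay compound 2 gives > 100000 nM, again a limit.

Compound 2 thus stands at the limit, as do both values shown (the limit of > 100000 nM in this assay, at which 2 of the 2 values shown sit). Within the data shown here, the one measured step, a step that the two limits leave unreadable from compound 1 to compound 2, is therefore unreadable in size. The change to compound 3 `COc1ccc(-c2nc3ncccn3c2NC2CCCCC2)cc1` is methyl in place of hydrogen on an oxygen on an aromatic ring. Among the measured compounds shown here, no measured step bears readably on it, so no step beyond the scatter is expected, which is what the estimated step that the limit leaves unreadable from compound 2 to compound 3 means. Compound 3 is expected at 150000 nM, within 60000 nM to 400000 nM.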

Compound 3, half-maximal cytotoxic concentration: > 100000 nM
Compound 3: only a limit was reported (the forecaster's own chance of this, stated with the estimate: 85%); the middle value is on the limit's open side.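

Compound 1, compound 2 and compound 3 all sit at the limit, so no step among them can be read in this assay: the limit of > 100000 nM in this assay, at which 3 of the 3 values shown sit.

The compounds shown leave open at what concentration any of the three becomes cytotoxic, and whether the group on the oxygen matters at all.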